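Replacing a Phenoxy Group with Fluoro: Effect on the Inhibition Reading

The compounds below may be only part of what the source reports. "The series", "measured", "known", "first", "only" and "open" are said of these compounds alone.

Measured compounds:
- compound 1, `N#Cc1ccc(Oc2cccnc2)cc1Oc1ccccc1`, 78%
- compound 2, `N#Cc1ccc(Oc2cccnc2)cc1Oc1cccc(Cl)c1`, 25%

Compound 1 is one of two compounds tested in an assay on isolated protein for inhibition of Aromatase (Homo sapiens), read by fluorescence, tested at 1 uM (on this read-out lower numbers stand for less inhibition and higher numbers for more inhibition at the one concentration tested (going by the name of the read-out)), and on these numbers compound 1 gives the higher reading. Compound 2 differs from compound 1 only by a chloro in place of hydrogen on an aromatic carbon, and this single change gave a number 53 percentage points lower from compound 1 to compound 2 (beyond the scatter) in this assay. That step shows the phenoxy part of compound 1 matters a great deal for the reading.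

Compound 3, `N#Cc1ccc(Oc2cccnc2)cc1F`, has not yet been measured in this assay. It differs from compound 1 by fluoro in place of phenoxy on an aromatic carbon. For the measured compounds named here, the only step known so far, the one from compound 1 to compound 2, concerns a substituent on that phenoxy ring, not the loss of the ring itself, so it is an indirect guide. Since a small addition on the phenoxy gave such a large drop, taking the whole phenoxy away and leaving a fluoro in its place is expected to lower the reading too, though the size is uncertain. The expected change is a number 40 percentage points lower from compound 1 to compound 3 (beyond the scatter). Compound 3 is therefore estimated at 38% in this assay, within a range from 8% to 70%.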

Compound 3, a percentage reported as inhibition, at one concentration (the size of the read-out at that concentration, not a potency): 15%
The estimate for compound 3 lay 23 percentage points above the measured number, within the range that was stated.
By their numbers in this assay, from the lowest: compounds 3 and 2 (each within the scatter of the next); then compound 1.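

The phenoxy group, on an aromatic carbon ortho to a cyano group, can now be judged as a whole rather than only through a substituent on its ring: in this assay, with fluoro in its place, the reading falls, giving a number 63 percentage points lower from compound 1 to compound 3 (beyond the scatter). This change removes a group of 7 heavy atoms, including a six-membered aromatic ring of carbon only and a hydrogen-bond acceptor, and leaves a single fluorine, so a high reading at this position does not survive on the rest of the core of compound 1 alone. No measured information available here explains why the reading moves in this way.

Because fluoro differs from phenoxy in several ways at once, this single step cannot show whether the reading depends on the aromatic ring, the oxygen that links it, or simply the size of the group at this place. From the compounds shown here alone, a methoxy group would keep the oxygen without the ring, while a benzyl group would keep a ring without that oxygen, and how either of these or an amine would read at this position remains open.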